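Dichloroanilino Variant in a Cytotoxicity Series

The compounds below may be only part of what the source reports. "The series", "measured", "known", "first", "only" and "open" are said of these compounds alone.

compound 1 `CN(C)CC(=O)NCCNc1cc(/C=C/c2ccccc2)nc2ccccc12`: 15000 nM
compound 2 `CCN(CC)CC(=O)NCCNc1cc(/C=C/c2ccccc2)nc2ccccc12`: 700 nM
compound 3 `O=C(CNc1ccccc1)NCCNc1cc(/C=C/c2ccccc2)nc2ccccc12`: 7800 nM

In an ADME assay on J774 cells (Mus musculus) for cytotoxicity, read by MTT assay, with a stated time of 48 h (on this read-out lower numbers stand for stronger inhibition and higher numbers for weaker inhibition), compound 3 gives 7800 nM, the second highest of the three numbers. Its nearest neighbour is compound 1, and a 1.9-fold lower number from compound 1 to compound 3 (0.28 log units; within the scatter) lies within the scatter, while an 11-fold higher number from compound 2 to compound 3 (1.05 log units; beyond the scatter) is a clear separation. Compound 4 `O=C(CNc1ccc(Cl)cc1Cl)NCCNc1cc(/C=C/c2ccccc2)nc2ccccc12` differs from compound 3 by 2,4-dichlorophenyl in place of phenyl on an amine nitrogen. Going by the values given here, the measured steps, a 21-fold lower number from compound 1 to compound 2 (1.33 log units; beyond the scatter) and an 11-fold higher number from compound 2 to compound 3 (1.05 log units; beyond the scatter), each exchange the whole amino group on the saturated chain carbon bound to the carbonyl carbon; only compound 3 carries a phenyl on that amine nitrogen, so no measured step bears on the present change. Compound 4 is therefore expected to show a 1.6-fold lower number from compound 3 to compound 4 (0.19 log units; within the scatter), a step not beyond the scatter. The estimate for compound 4 is 5000 nM, ranging from 1500 nM to 16000 nM.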

Compound 4, half-maximal inhibitory concentration: > 50000 nM
Compound 4: only a limit was reported (the forecaster's own chance of this, stated with the estimate: 5%); middle value at least 10-fold (1.00 log units) from the limit.
By their numbers in this assay, from the lowest: compound 2; then compounds 3 and 1 (each within the scatter of the next). At a limit, above all of these: compound 4.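

In this assay compound 4 gives only a limit, not a number: the limit of > 50000 nM in this assay, at which 1 of the 4 values shown sits. Putting 2,4-dichlorophenyl in place of phenyl on the amine nitrogen gives an at least 6.4-fold higher number from compound 3 to compound 4 (0.80 log units; beyond the scatter), showing what the earlier exchanges of the whole amino group could not: the number at this position responds to substitution on the phenyl itself. The change also sets the compound apart from the two alkylamino compounds, with an at least 71-fold higher number from compound 2 to compound 4 (1.85 log units; beyond the scatter) and an at least 3.3-fold higher number from compound 1 to compound 4 (0.52 log units; beyond the scatter). The compounds shown leave open whether a single chlorine on the phenyl, or a methoxy group there, would move the number in the same way.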